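Adding a Second Methoxy Group to a Styryl Pyranone

The compounds below may be only part of what the source reports. "The series", "measured", "known", "first", "only" and "open" are said of these compounds alone.

Of the compounds shown here, two sharing one core have been measured. Compound 1 `O=c1ccoc(/C=C/c2ccccc2)c1` carries a bare benzene ring; in a functional assay on NCI-H460 cells (Homo sapiens) for inhibition, read by sulforhodamine B assay, with a stated time of 48 h (a higher number here means a weaker inhibitor of growth, a lower number a stronger inhibitor of growth), compound 1 gives 509 uM. Compound 2 `COc1ccc(/C=C/c2cc(=O)cco2)cc1` carries a methoxy group on that ring, and in this assay compound 2 gives 606 uM. That change produced a 1.2-fold higher number from compound 1 to compound 2 (0.08 log units; within the scatter), so compound 2 and compound 1 cannot be told apart here, and compound 2 stands simply alongside compound 1. Compound 3 `COc1ccc(/C=C/c2cc(=O)cco2)cc1OC` has not yet been measured. It differs from compound 2 by methoxy in place of hydrogen on an aromatic carbon. Going by the values given here, the only measured step that bears on adding a methoxy group is the one from compound 1 to compound 2, which stayed within the scatter. A second methoxy group is therefore expected to move the number little, and the estimated step is a 1.0-fold lower number from compound 2 to compound 3 (0.00 log units; within the scatter), in no firm direction. For compound 3 the value in this assay is estimated at 600 uM, with a range from 250 uM to 1400 uM.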

Compound 3, concentration for growth inhibition (reported as GI): 546 uM
Compound 3: the middle estimate sits 1.1-fold (0.04 log units) above what was measured, and the stated range covers the measured number.
By their numbers in this assay, from the lowest: compounds 1, 3 and 2 (each within the scatter of the next).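

The step at this new position, ortho to a methoxy group and meta to a group of 9 heavy atoms, is a 1.1-fold lower number from compound 2 to compound 3 (0.05 log units; within the scatter) in this assay. The methoxy step at the first position, a 1.2-fold higher number from compound 1 to compound 2 (0.08 log units; within the scatter), also lay within the scatter, so in this short series neither methoxy addition gives a difference that can be told apart from ordinary variation between repeated measurements, even when the second sits ortho to the first. No available measurement offers a reason for this result.

On these data alone, what remains open is whether a different group at this position, such as a hydroxyl, an amine or a carboxylic acid, would give a step beyond the scatter. A longer chain such as ethoxy or propoxy in place of the methoxy group is likewise untested by the compounds shown here.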